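Methoxy removal on a biaryl urea antagonist series

The source may hold more compounds than are shown below. What is called first, only, known or untested is meant among the compounds shown, and "the series" means these compounds.

The account concerns four ureas examined in an in vitro functional assay on HEK293 cells for antagonist activity at melanin-concentrating hormone receptor 1 (Homo sapiens), read by GTPgammaS binding, with a stated time of 45 min; on this read-out higher numbers stand for higher potency (the scale is a negative logarithm) and lower numbers for lower potency. Compound 1 `COc1ccccc1-c1ccc(CNC(=O)NC2CCN(Cc3ccc(C)cc3)CC2)cc1` gives 6.19 in this assay. Compound 2 `Cc1ccc(CN2CCC(NC(=O)NCc3ccc(-c4ccccc4)cc3)CC2)cc1` gives 5.98 in this assay, the step of a number 0.21 log units lower from compound 1 to compound 2 (within the scatter) corresponding to hydrogen in place of methoxy on an aromatic carbon. Compound 3 `COc1ccc(-c2ccc(CN(CCC3CCN(Cc4ccc(C)cc4)CC3)C(=O)NC(C)(C)COC(C)=O)cc2)cc1` gives 6.19 in this assay, level with compound 1 at the digits shown; the difference between the core of compound 3 and the core of compound 1 is not broken down here. Compound 4 `CC(=O)OCC(C)(C)NC(=O)N(CCC1CCN(Cc2ccc(C)cc2)CC1)Cc1ccc(-c2ccccc2)cc1` is not yet measured and differs from compound 3 by hydrogen in place of methoxy on an aromatic carbon, which is the same kind of change as that from compound 1 to compound 2, though there the methoxy sat ortho to a large group and here it sits para to a large group. Resting on the step of a number 0.21 log units lower from compound 1 to compound 2 (within the scatter), the step from compound 3 to compound 4 is expected to be small, a number 0.14 log units lower from compound 3 to compound 4 (within the scatter) in this assay. Compound 4 is therefore estimated at 6.05, between 5.6 and 6.5, in this assay.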

Compound 4, negative logarithm of the antagonist equilibrium constant: 6.44
Compound 4: middle estimate off by 0.39 log units, on the low side, and the stated range covers the measured number.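

Replacing methoxy with hydrogen does not carry over from one core to the other as a single fixed step in this assay: the same change on two cores in this assay, a number 0.21 log units lower (within the scatter) from compound 1 to compound 2 and a number 0.25 log units higher (within the scatter) from compound 3 to compound 4, 0.46 log units apart, beyond the scatter of two such steps. Taken alone, the new step is a number 0.25 log units higher from compound 3 to compound 4 (within the scatter), so neither step by itself shows a real change, and only the gap between the two steps lies beyond the scatter. With just two pairs, which also differ in where the methoxy sits, the data do not show whether the core or that position accounts for the gap.

The compounds shown leave open how other groups would behave at this place. A chlorine or an amine para to a large group, for instance, could follow either step or neither.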